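Acyl for aryl on the ring nitrogen: cytotoxicity notes

This account rests on a few compounds, and the source may have more. Where it says the series, first, only, none or still open, it means among the compounds named here.

Measured so far:
compound 1 `NCCNc1cc(N2CCN(c3cccc(Cl)c3)CC2)nc2ccccc12`: 6400 nM
compound 2 `NCCNc1cc(N2CCN(C(=O)C3(c4ccccc4)CC3)CC2)nc2ccccc12`: > 100000 nM (a limit of the assay, not a number)

Going by the values given here, in an ADME assay on HEp-2 cells (Homo sapiens) for cytotoxicity, read by CCK-8 assay, with a stated time of 6 days (on this read-out higher numbers stand for lower toxicity in this test and lower numbers for higher toxicity in this test), compound 1 gives 6400 nM, the only plain number in the set. Compound 2 gives > 100000 nM, which is a limit of the assay rather than a number. Compound 2 carries a carbonyl on the amine nitrogen in the ring, as compound 3 `NCCNc1cc(N2CCN(C(=O)C3CCCCC3)CC2)nc2ccccc12` does. Compound 3 differs from compound 1 by cyclohexylcarbonyl in place of 3-chlorophenyl on an amine nitrogen in a ring. Among the compounds with values here, no measured step connects the two; the step of a 13-fold higher number from compound 1 to compound 3 (1.10 log units; beyond the scatter) is expected to be large, toward lower toxicity, since compound 2 sits at the limit of > 100000 nM in this assay, at which 1 of the 2 values shown sits. Compound 3 is estimated at 80000 nM, with a range from 20000 nM to 150000 nM.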

Compound 3, half-maximal cytotoxic concentration: > 100000 nM
Compound 3: no number, only a limit (the forecaster's own chance of this, stated with the estimate: 60%); middle value at least 1.2-fold (0.09 log units) away from the limit.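

In this assay, cyclohexylcarbonyl in place of 3-chlorophenyl on an amine nitrogen in a ring gives an at least 15-fold higher number from compound 1 to compound 3 (1.19 log units; beyond the scatter) and so puts a first measured step, toward lower toxicity in this test, at this position. The reading for compound 3 is a limit of the assay and not a number, as is that for compound 2: the limit of > 100000 nM in this assay, at which 2 of the 3 values shown sit. The step between these two cannot be read, so cyclohexyl and 1-phenylcyclopropyl on the carbonyl carbon stay unranked.

Still open, as far as these compounds go, is whether the carbonyl or the change of ring carries the step. A benzyl group or a plain cyclohexyl on that nitrogen would bear on this.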